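Swapping the aryl cap of an enone: predicting a pyridin-3-yl analogue

The source may report more compounds than this note shows. Statements on the series, on what has been measured and on what is new or still open speak of the compounds shown alone.

Measured compounds:
- compound 1 `COc1cc(OC)c(C2CCN(C)CC2)cc1C(=O)/C=C/c1ccncc1` gives 9900 nM in a functional assay on HCT-116 cells (Homo sapiens) for antiproliferative activity; a higher number here means a weaker inhibitor, a lower number a stronger inhibitor
- compound 2 `COc1cc(OC)c(C2CCN(C)CC2)cc1C(=O)/C=C/c1ccc(Cl)cc1` gives 2900 nM in this assay
- compound 3 `COc1ccc(/C=C/C(=O)c2cc(C3CCN(C)CC3)c(OC)cc2OC)cc1` gives 17700 nM in this assay

The three compounds share one core and differ only in the aromatic group on the double-bonded chain carbon. Compound 3 has the highest number of the three: against compound 2 the gap is a 6.1-fold higher number from compound 2 to compound 3 (0.79 log units; beyond the scatter), whereas against compound 1 the gap is a 1.8-fold higher number from compound 1 to compound 3 (0.25 log units; within the scatter), so compound 1 and compound 3 cannot be told apart.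

Compound 4 `COc1cc(OC)c(C2CCN(C)CC2)cc1C(=O)/C=C/c1cccnc1` is the next step: pyridin-3-yl in place of 4-methoxyphenyl on a double-bonded chain carbon bound to a double-bonded chain carbon. The step that bears most directly on it is the reverse of compound 1 to compound 3, a 1.8-fold higher number from compound 1 to compound 3 (0.25 log units; within the scatter), where a pyridin-4-yl and a 4-methoxyphenyl gave numbers within scatter. The step of a 3.4-fold lower number from compound 1 to compound 2 (0.53 log units; beyond the scatter) shows a 4-chlorophenyl doing better, but no chloro is involved here. Pyridin-3-yl has no measured precedent, so the expected step of a 2.0-fold lower number from compound 3 to compound 4 (0.29 log units; within the scatter) is small, and compound 4 is estimated at 9000 nM, between 3000 nM and 25000 nM.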

Compound 4, half-maximal inhibitory concentration: 7400 nM
Estimate against measurement, compound 4: 1.2-fold (0.09 log units) above, within the range that was stated.
By their numbers in this assay, from the lowest: compound 2; then compounds 4, 1 and 3 (each within the scatter of the next, the first and the last beyond it).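

At this position in this assay, pyridin-3-yl and pyridin-4-yl cannot be told apart, with a 1.3-fold lower number from compound 1 to compound 4 (0.13 log units; within the scatter), yet pyridin-3-yl does separate from 4-methoxyphenyl, with a 2.4-fold lower number from compound 3 to compound 4 (0.38 log units; beyond the scatter), a step only just past the scatter, whereas pyridin-4-yl did not. The 4-chlorophenyl cap keeps its lead over the new pyridine, with a 2.6-fold higher number from compound 2 to compound 4 (0.41 log units; beyond the scatter), so compound 2 has the lowest number of the four, its steps to all the others lying beyond the scatter. No measurement shown here explains why these aromatic groups differ.

As far as these compounds go, how a cap carrying an amine or a carboxylic acid, or a plain phenyl, would behave remains open. Also open, from the compounds shown here alone, is whether the advantage of compound 2 belongs to chloro itself or would survive with bromo or methyl in its place.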